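The source may report more compounds than this note shows. Statements on the series, on what has been measured and on what is new or still open speak of the compounds shown alone.

Measured so far:
compound 1 `COc1ccc(OC)c(Sc2ccc3nnc(-c4ccccc4)n3n2)c1` — 1380 nM
compound 2 `COc1ccc(OC)c(Sc2ccc3nnc(-c4ccccn4)n3n2)c1` — 1310 nM
compound 3 `COc1cncc(-c2nnc3ccc(Sc4cc(OC)ccc4OC)nn23)c1` — 440 nM

In an assay on HEK293 cells for inhibition of Leucine-rich repeat serine/threonine-protein kinase 2 (Homo sapiens), read by ELISA, with a stated time of 90 min (a lower number here means a stronger inhibitor, a higher number a weaker inhibitor), compound 2 gives 1310 nM, the second highest of the three numbers. Compound 1 stands nearest to it, and the two are indistinguishable a 1.1-fold lower number from compound 1 to compound 2 (0.02 log units; within the scatter). Compound 3 stands furthest, with a modest gain a 3.0-fold lower number from compound 2 to compound 3 (0.47 log units; beyond the scatter).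

Compound 4 `COc1ccc(OC)c(Sc2ccc3nnc(-c4cn(C)nc4C)n3n2)c1` is not yet measured. It differs from compound 2 in one place: 1,3-dimethyl-1H-pyrazol-4-yl in place of pyridin-2-yl on an aromatic carbon

All three measured steps vary the same aromatic substituent on the shared core. From compound 1, the change to pyridin-2-yl gave a 1.1-fold lower number from compound 1 to compound 2 (0.02 log units; within the scatter), while 5-methoxypyridin-3-yl gave a 3.1-fold lower number from compound 1 to compound 3 (0.50 log units; beyond the scatter) and, from compound 2, a 3.0-fold lower number from compound 2 to compound 3 (0.47 log units; beyond the scatter). Going by the values given here, none of these involves a five-membered ring or the 1,3-dimethyl-1H-pyrazol-4-yl group, so there is no direct precedent; the measured steps only show that this position tolerates a change of aryl group with at most modest movement in this assay.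

A step in this assay no larger than modest is expected, with the direction uncertain and a somewhat lower number slightly favoured given a 3.0-fold lower number from compound 2 to compound 3 (0.47 log units; beyond the scatter). Compound 4 is therefore estimated at 800 nM, with a range of 250 nM to 2500 nM. This estimate corresponds to an expected step of a 1.6-fold lower number from compound 2 to compound 4 (0.21 log units; within the scatter).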

Compound 4, half-maximal inhibitory concentration: 1260 nM
For compound 4 the middle estimate is 1.6-fold (0.20 log units) below the measured one, and the stated range covers the measured number.
By their numbers in this assay, from the lowest: compound 3; then compounds 4, 2 and 1 (each within the scatter of the next).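

In this assay the 1,3-dimethyl-1H-pyrazol-4-yl group brings a five-membered aromatic ring with 2 hetero atoms to this position, and the number holds level with the six-membered groups of the two nearest compounds, with a 1.0-fold lower number from compound 2 to compound 4 (0.02 log units; within the scatter) and a 1.1-fold lower number from compound 1 to compound 4 (0.04 log units; within the scatter) both within the scatter. Compound 3 alone stands apart among the four, with a 2.9-fold higher number from compound 3 to compound 4 (0.46 log units; beyond the scatter), so in these compounds neither ring size nor the number of ring hetero atoms goes with a step beyond the scatter. Nothing at hand accounts for this level result or for the separate place of compound 3.

From the compounds shown here alone, it remains open whether the methoxy group or the ring nitrogen of 5-methoxypyridin-3-yl carries the difference, which an unsubstituted pyridin-3-yl would help separate. Going by these compounds, how an amine or a carboxylic acid on the aryl group would read at this position is also open.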